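The compounds below may be only part of what the source reports. "The series", "measured", "known", "first", "only" and "open" are said of these compounds alone.

Measured so far, in a functional assay for inhibition, with Cavia porcellus as the target; a lower number here means a stronger inhibitor, a higher number a weaker inhibitor:

Compound 1 `N=C(N)c1ccc(C(=O)NCC[C@H]2C(=O)N(CC(=O)O)CCN2C(=O)CNC(=O)c2ccc(C(=N)N)cc2)cc1` gives 190 nM.
Compound 2 `N=C(N)c1ccc(C(=O)NCCC[C@H]2C(=O)N(CC(=O)O)CCN2C(=O)CNC(=O)c2ccc(C(=N)N)cc2)cc1` gives 37 nM.
Compound 3 `N=C(N)Nc1ccc(C(=O)NCCC[C@H]2C(=O)N(CC(=O)O)CCN2C(=O)CNC(=O)c2ccc(NC(=N)N)cc2)cc1` gives 51 nM.

Compound 2 and compound 3 lie within the usual scatter of each other in this assay, so no order between them is claimed. Compound 1 lies beyond the scatter from compound 2, at a higher number, and is the furthest of the three from it. No pair of these compounds differs in one place only, so no single step among the measured compounds is available.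

Compound 4 `N=C(N)c1ccc(C(=O)NCC(=O)N2CCN(CC(=O)O)C(=O)[C@@H]2CCCNC(=O)CCCCN)cc1` is not yet measured. Relative to compound 2 the change is a group of 5 heavy atoms (4 carbon, 1 nitrogen; no ring) in place of a group of 9 heavy atoms (7 carbon, 2 nitrogen; one six-membered aromatic ring of carbon only), on a carbonyl carbon. The entering group is 4-aminobutyl. All three measured compounds carry two amidine-bearing aromatic arms; compound 4 keeps only one, and nothing measured tells how that is tolerated.

The step of a 9.5-fold higher number from compound 2 to compound 4 (0.98 log units; beyond the scatter) is expected to be a loss beyond the scatter, toward a higher number. Compound 4 is estimated at 350 nM, within 80 nM to 2000 nM.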

Compound 4, half-maximal inhibitory concentration: 210 nM
Compound 4: the middle estimate sits 1.7-fold (0.22 log units) above what was measured, and the stated range covers the measured number.
By their numbers in this assay, from the lowest: compounds 2 and 3 (each within the scatter of the next); then compounds 1 and 4 (each within the scatter of the next).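

In this assay, putting 4-aminobutyl on the carbonyl carbon in place of the group bearing the six-membered aromatic ring gives a 5.7-fold higher number from compound 2 to compound 4 (0.75 log units; beyond the scatter), a loss beyond the scatter, yet compound 4 still reads 210 nM and so keeps inhibition with a single aromatic arm. At the level of the whole side chain, on the saturated chain carbon, a group of 9 heavy atoms without a ring stands in place of a group of 12 heavy atoms with the aromatic ring, and a 1.1-fold higher number from compound 1 to compound 4 (0.04 log units; within the scatter) lies within the scatter, so these two compounds are not separated. No supporting measurement bears on this result, and the size of the step stays unexplained.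

Since only 4-aminobutyl has been seen at this place, the step cannot be assigned to losing the aromatic ring rather than to the particular chain that enters, and a longer chain, or a carboxylic acid in place of the amine, would help to separate the two. Also open is whether the other aromatic arm takes the same replacement, since every compound shown keeps at least one such arm.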